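This account rests on a few compounds, and the source may have more. Where it says the series, first, only, none or still open, it means among the compounds named here.

Working notes on the series.

The three measured compounds share a core and a terminal (2-aminophenyl)carbamoyl group, and all three were read in a functional assay on MV4-11 cells (Homo sapiens) for antiproliferative activity, read by CCK-8 assay, with a stated time of 72 h; on this read-out higher numbers stand for weaker inhibition and lower numbers for stronger inhibition. Compound 1 `Cn1cc(-c2ccccc2Oc2ccccc2)c2cc(C(=O)NCCCCC(=O)Nc3ccccc3N)[nH]c2c1=O` gives 240 nM. Compound 2 `Cc1cc(F)cc(C)c1Oc1ccc(C(C)(C)O)cc1-c1cn(C)c(=O)c2[nH]c(C(=O)NCc3ccc(C(=O)Nc4ccccc4N)cc3)cc12` gives 240 nM, level with compound 1 at the digits shown, so the two sit together at the high end of the three numbers, with no change between them beyond the scatter. Compound 3 `Cn1cc(-c2cccc(F)c2)c2cc(C(=O)NCc3ccc(C(=O)Nc4ccccc4N)cc3)[nH]c2c1=O` gives 210 nM, a number that lies within the scatter of compound 1 as well, so on these numbers the three compounds are not separated in this assay.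

Compound 4 `Cn1cc(-c2ccccc2Oc2ccccc2)c2cc(C(=O)NCCCCCCC(=O)Nc3ccccc3N)[nH]c2c1=O` is the next compound to be measured in this assay. It differs from compound 1 in one place: 2-((2-aminophenyl)carbamoyl)ethyl in place of (2-aminophenyl)carbamoyl on a saturated chain carbon, four bonds along the chain from an amide-type nitrogen. Among the measured compounds shown here, no step of this kind between measured compounds exists, so nothing measured shows its size or direction. The expectation is a step from compound 1 to compound 4 of a 1.2-fold higher number from compound 1 to compound 4 (0.07 log units; within the scatter), not beyond the scatter. Compound 4 is estimated at 280 nM, in the range 120 nM to 650 nM.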

Compound 4, half-maximal inhibitory concentration: 130 nM
For compound 4 the middle estimate is 2.2-fold (0.33 log units) above the measured one, and the stated range covers the measured number.
By their numbers in this assay, from the lowest: compounds 4, 3, 1 and 2 (each within the scatter of the next).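

In this assay, among the compounds shown here, this is the first step at this position, on a saturated chain carbon, four bonds along the chain from an amide-type nitrogen: 2-((2-aminophenyl)carbamoyl)ethyl in place of (2-aminophenyl)carbamoyl gives a 1.8-fold lower number from compound 1 to compound 4 (0.27 log units; within the scatter) and stays within the scatter. The position therefore takes the larger group, and the read-out is not separated from that of compound 1. No evidence on hand bears on this result.

A single step in one direction cannot show whether a longer chain at this position would move the number beyond the scatter or leave it within. Also open, going by these compounds, is whether a hydroxamic acid in place of the (2-aminophenyl)carbamoyl group would hold the read-out on this same chain.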